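This account rests on a few compounds, and the source may have more. Where it says the series, first, only, none or still open, it means among the compounds named here.

Two members of the series have been measured: compound 1 `COc1ccc(CN2CCC=C(CCC(=O)NO)C2=O)cc1` and compound 2 `O=C(CCC1=CCCN(CCCc2ccc(-c3ccccc3)cc2)C1=O)NO`, which share a core and differ in the substituent on the ring nitrogen. In a functional assay on PC-3 cells (Homo sapiens) for inhibition, read by sulforhodamine B assay (a higher number here means a weaker inhibitor of growth, a lower number a stronger inhibitor of growth), compound 1 gives 7080 nM, the higher of the two numbers. Compound 2 gives 3230 nM in this assay, a lower number than compound 1 and beyond the scatter. Compound 3 `O=C(CCC1=CCCN(Cc2ccc(NC(=O)c3ccccc3)cc2)C1=O)NO` remains unmeasured; it differs from compound 1 by benzamido in place of methoxy on an aromatic carbon. Expected in this assay is a moderate drop in the number, the step of a 2.4-fold lower number from compound 1 to compound 3 (0.37 log units; beyond the scatter), somewhat beyond the scatter. Compound 3 is estimated at 3000 nM, with a range from 1000 nM to 9000 nM.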

Compound 3, concentration for 50% growth inhibition: > 10000 nM
Compound 3 ended at the assay's limit; the forecaster's own chance of this, stated with the estimate: 5%; middle value at least 3.3-fold (0.52 log units) away from the limit.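

In this assay compound 3 gives > 10000 nM and that value is a limit of the assay, not a number. On this aromatic carbon, para to a large group, benzamido in place of methoxy does not lower the number: the step is an at least 1.4-fold higher number from compound 1 to compound 3 (0.14 log units; that floor lies within the scatter) and only its floor can be read. Going by these compounds alone, this is the first view of a change at this position, and the larger group brings no gain in growth inhibition here.

Going by these compounds, how far compound 3 lies past the limit stays open. Also open, on these data alone, is what an amine or a carboxylic acid on this aromatic carbon would do to the number.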